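The source may hold more compounds than are shown below. What is called first, only, known or untested is meant among the compounds shown, and "the series" means these compounds.

Within the data shown here, in an ADME assay on HOS cells (Homo sapiens) for cytotoxicity, read by a luciferase reporter and ATP content (a lower number here means that less compound is tolerated, a higher number that more compound is tolerated), compound 2 `O=C(NCc1ccc(F)cc1F)c1c(NCCCCc2ccccc2)c2cccnc2n(O)c1=O` gives 102000 nM, the higher of the two numbers so far, while compound 1 `CN(C)c1c(C(=O)NCc2ccc(F)cc2F)c(=O)n(O)c2ncccc12` gives 13000 nM. Compound 3 `O=C(NCc1ccc(F)cc1F)c1c(NCCO)c2cccnc2n(O)c1=O` differs from compound 2 at the end of its chain: hydroxy in place of phenethyl on a saturated chain carbon, two bonds along the chain from a nitrogen on an aromatic ring. Among the measured compounds shown here, the one measured step that bears on this is a 7.8-fold higher number from compound 1 to compound 2 (0.89 log units; beyond the scatter), modest but beyond the scatter, where (4-phenylbutyl)amino replaced dimethylamino. With (2-hydroxyethyl)amino in place of (4-phenylbutyl)amino, a partial return towards the value of compound 1 at 13000 nM is expected, meaning a lower number in this assay. The expected change is a 2.9-fold lower number from compound 2 to compound 3 (0.46 log units; beyond the scatter). For compound 3 the estimate is 35000 nM, with a range of 10000 nM to 110000 nM.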

Compound 3, half-maximal cytotoxic concentration: 24000 nM
For compound 3 the middle estimate is 1.5-fold (0.16 log units) above the measured one; the measured number falls inside the stated range.
By their numbers in this assay, from the lowest: compounds 1 and 3 (each within the scatter of the next); then compound 2.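

In this assay the shorter chain gives a 4.3-fold lower number from compound 2 to compound 3 (0.63 log units; beyond the scatter) and so loses most of the rise seen with (4-phenylbutyl)amino. Replacing dimethylamino with (2-hydroxyethyl)amino gives a 1.8-fold higher number from compound 1 to compound 3 (0.27 log units; within the scatter) and so does not separate these two groups, leaving compound 2 alone apart from the others. Nothing available accounts for this difference. Still open, on these data alone, is whether the number of compound 2 follows its phenyl ring or its chain length. A plain butylamino group would bear on this, and an amine or carboxylic acid in place of the hydroxy would test the chain end.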